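This account rests on a few compounds, and the source may have more. Where it says the series, first, only, none or still open, it means among the compounds named here.

Compound 3 `NS(=O)(=O)NCCC1CCN(c2cc(-c3ccccc3)ncn2)CC1` gives, in a functional assay on M21 cells (Homo sapiens) for antiproliferative activity, read by sulforhodamine B assay, with a stated time of 48 h (on this read-out higher numbers stand for weaker inhibition of growth and lower numbers for stronger inhibition of growth), only a limit, > 100000 nM. Compound 1 `NS(=O)(=O)NCC1CCN(c2cc(-c3ccccc3)ncn2)CC1` likewise sits at a limit, > 100000 nM. Compound 2 `NS(=O)(=O)NCC1CCN(c2cc(-c3ccc(C(F)(F)F)cc3)ncn2)CC1` gives a number in this assay, 43100 nM. Compound 4 `CCOC(=O)c1ccc(-c2cc(N3CCC(CCNS(N)(=O)=O)CC3)ncn2)cc1` differs from compound 3 by ethoxycarbonyl in place of hydrogen on an aromatic carbon. The measured step that bears on this change is an at least 2.3-fold lower number from compound 1 to compound 2 (0.36 log units; beyond the scatter), which also places a group on an aromatic carbon para to a large group. The step that the two limits leave unreadable from compound 1 to compound 3 cannot be read, since both of its values rest on (the limit of > 100000 nM in this assay, at which 2 of the 3 values shown sit). A modest lowering of the number is therefore expected from compound 3 to compound 4, an at least 1.6-fold lower number from compound 3 to compound 4 (0.22 log units; that floor lies within the scatter), though a limit may still be reported. Compound 4 is estimated at 60000 nM, within a range from 20000 nM to 200000 nM.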

Compound 4, concentration for 50% growth inhibition: 9000 nM
Compound 4: middle estimate off by 6.7-fold (0.82 log units), on the high side; measured number below the stated range.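

In this assay, ethoxycarbonyl on the aromatic carbon para to a large group gives an at least 11-fold lower number from compound 3 to compound 4 (1.04 log units; beyond the scatter). A group at this position can therefore turn a limit into a measured number on the longer side chain too, not only on the shorter one of compound 1. The true size of the step stays unknown, since the starting point is a limit of the assay: the limit of > 100000 nM in this assay, at which 2 of the 4 values shown sit.

What the compounds shown leave open is whether a carboxylic acid or an amide at this carbon would serve as well. Also open, as far as these compounds go, is how ethoxycarbonyl would act on the shorter side chain of compound 1.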